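The compounds below may be only part of what the source reports. "The series", "measured", "known", "first", "only" and "open" are said of these compounds alone.

Measured so far:
compound 1, `COc1cccc(OC(=O)c2ccc(O)cc2)c1OC(=O)c1ccc(O)cc1`: 86.5%
compound 2, `O=C(Oc1ccc(Cl)cc1OC(=O)c1ccc(O)cc1)c1ccc(O)cc1`: 79%
compound 3, `O=C(Oc1cccc(F)c1OC(=O)c1ccc(O)cc1)c1ccc(O)cc1`: 92.6%

In a functional assay on NCI-H1299 cells (Homo sapiens) for inhibition, read by scintillation counting, with a stated time of 30 min, tested at 30 uM (a higher number here means more inhibition at the concentration tested (going by the name of the read-out), a lower number less inhibition), compound 3 gives the highest of the three numbers; compound 1 stands within the scatter of it, compound 2 beyond it. Among the measured compounds shown here, the only measured single-change step, fluoro in place of methoxy on an aromatic carbon, gave a number 6.1 percentage points higher from compound 1 to compound 3 (within the scatter), within the scatter.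

Compound 4, `O=C(Oc1ccccc1OC(=O)c1ccc(O)cc1)c1ccc(O)cc1`, differs from compound 3 by hydrogen in place of fluoro on an aromatic carbon. For the measured compounds named here, no measured step takes fluoro to hydrogen; the one step that touches this group, a number 6.1 percentage points higher from compound 1 to compound 3 (within the scatter), stayed within the scatter. Compound 4 is therefore expected to move no further than the scatter, as a number 4.6 percentage points lower from compound 3 to compound 4 (within the scatter). Compound 4 is estimated at 88%, between 75% and 98%.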

Compound 4, a percentage reported as inhibition, at one concentration (the size of the read-out at that concentration, not a potency): 57.5%
Beside the measured number, compound 4's estimate is 30.5 percentage points above it, and the stated range ends above it.
By their numbers in this assay, from the lowest: compound 4; then compounds 2, 1 and 3 (each within the scatter of the next, the first and the last beyond it).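

In this assay, hydrogen in place of fluoro gave a number 35.1 percentage points lower from compound 3 to compound 4 (beyond the scatter), hydrogen in place of chloro gave a number 21.5 percentage points lower from compound 2 to compound 4 (beyond the scatter), and hydrogen in place of methoxy gave a number 29 percentage points lower from compound 1 to compound 4 (beyond the scatter). The earlier compounds shown here showed only that exchanging fluoro and methoxy stayed within the scatter; now all three compounds carrying a group on this ring stand above compound 4, which carries none. Having a group there therefore counts for more in this series than the differences among these three groups.

On these data alone, whether an amine or a carboxylic acid on this carbon would hold the inhibition remains open. Nothing measured here accounts for the drop.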